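Compound 4: 3,4-dimethoxyphenyl in place of 3,4-dihydroxyphenyl

A few compounds are considered here, and "the series" means these few. Any claim that something is new, unique, unknown or untested is made for them only; others in the source may bear on it.

The compounds share one core and differ in the aromatic group on the double-bonded chain carbon. In a functional assay on MCF7 cells (Homo sapiens) for cytotoxicity, read by MTT assay, with a stated time of 48 h (a lower number here means a stronger inhibitor, a higher number a weaker inhibitor), compound 1 (`O=C1/C(=C\c2ccc(O)cc2)S/C(=N/c2ccccc2)N1Cc1ccncc1`) gives 18900 nM, compound 2 (`CN(C)c1ccc(/C=C2/S/C(=N/c3ccccc3)N(Cc3ccncc3)C2=O)cc1`) gives 76300 nM and compound 3 (`O=C1/C(=C\c2ccc(O)c(O)c2)S/C(=N/c2ccccc2)N1Cc1ccncc1`) gives 12400 nM. Compound 3 cannot be separated from compound 1, as the data show a 1.5-fold lower number from compound 1 to compound 3 (0.18 log units; within the scatter). It does stand clear of compound 2, with a 6.2-fold lower number from compound 2 to compound 3 (0.79 log units; beyond the scatter).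

Compound 4 (`COc1ccc(/C=C2/S/C(=N/c3ccccc3)N(Cc3ccncc3)C2=O)cc1OC`) carries 3,4-dimethoxyphenyl in place of 3,4-dihydroxyphenyl on a double-bonded chain carbon bound to a double-bonded ring carbon.

Among the compounds with values here, no measured compound carries a methoxy group, so the evidence is indirect. Within the data shown here, the nearest guide is the replacement of hydroxy by dimethylamino, which gave a 4.0-fold higher number from compound 1 to compound 2 (0.61 log units; beyond the scatter), and compound 2 is also the only measured compound without a hydroxy group. That is one compound against two, not an established pattern, and dimethylamino is a poor stand-in for methoxy. A modest move towards the number of compound 2 therefore seems likelier than none, with wide uncertainty. The expected step is a 2.1-fold higher number from compound 3 to compound 4 (0.32 log units; beyond the scatter). In this assay the estimate for compound 4 is 26000 nM, expected to fall between 11000 nM and 62000 nM.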

Compound 4, half-maximal inhibitory concentration: 80700 nM
Estimate against measurement, compound 4: 3.1-fold (0.49 log units) below; measured number outside the range, above it.
By their numbers in this assay, from the lowest: compounds 3 and 1 (each within the scatter of the next); then compounds 2 and 4 (each within the scatter of the next).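

In this assay the two hydroxy groups of compound 3 cannot be exchanged for methoxy groups without a clear loss (a 6.5-fold higher number from compound 3 to compound 4 (0.81 log units; beyond the scatter)), and compound 4 also stands apart from the 4-hydroxyphenyl member of the series (a 4.3-fold higher number from compound 1 to compound 4 (0.63 log units; beyond the scatter)). Compound 4 cannot be separated from compound 2 (a 1.1-fold higher number from compound 2 to compound 4 (0.02 log units; within the scatter)), so the result for the dimethylamino group no longer stands alone: two quite different groups without a hydroxy now sit together. Across these four compounds, the aromatic groups bearing hydroxy (compounds 1 and 3) lie apart from those without it (compounds 2 and 4), with no compound against this split, and the oxygen atoms alone do not keep the number of compound 3, since 3,4-dimethoxyphenyl holds as many as 3,4-dihydroxyphenyl.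

Nothing at hand gives a reason for this split.

Open, on these data alone, is whether one hydroxy and one methoxy on the same phenyl, a plain phenyl, an amine or a carboxylic acid at this place would fall with compounds 1 and 3 or with compounds 2 and 4.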